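The compounds below may be only part of what the source reports. "The series", "measured", "known", "first", "only" and "open" are said of these compounds alone.

Measured so far:
compound 1 `COc1ccccc1NC(=O)c1ccc2cccc(O)c2n1` – 2.5
compound 2 `O=C(Nc1ccccc1Cl)c1ccc2cccc(O)c2n1` – 2.5

Compound 2 `O=C(Nc1ccccc1Cl)c1ccc2cccc(O)c2n1` and compound 1 `COc1ccccc1NC(=O)c1ccc2cccc(O)c2n1` share one core and differ only in the group on the aromatic carbon of the outer ring. In a physicochemical assay for lipophilicity, read by HPLC (a higher number here means a more lipophilic compound, a lower number a more polar compound), compound 1 gives 2.5, and compound 2 gives 2.5; the step of no change at the digits printed from compound 1 to compound 2 (within the scatter) lies within the scatter, so compound 2 stands level with compound 1 on the numbers shown.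

Compound 3 `O=C(Nc1ccccc1[N+](=O)[O-])c1ccc2cccc(O)c2n1` is the next member of the series. Relative to compound 2 the change is nitro in place of chloro on an aromatic carbon, ortho to a large group. Among the compounds with values here, only one measured step bears on it, no change at the digits printed from compound 1 to compound 2 (within the scatter), and that step exchanged methoxy for chloro at the same carbon without any shift beyond the scatter. It is a different exchange from the one at hand, so it gives only weak guidance.

For compound 3 a modest downward step, a number 0.30 log units lower from compound 2 to compound 3 (within the scatter), is expected in this assay, with the estimate 2.2 and a range from 1.7 to 2.7.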

Compound 3, partition coefficient: 2.5
The estimate for compound 3 lay 0.30 log units below the measured number; low and high end bracket the measured number.
By their numbers in this assay, from the lowest: compounds 1, 2 and 3 (each within the scatter of the next).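

With nitro in place of chloro on an aromatic carbon, ortho to a large group, this assay shows no change at the digits printed from compound 2 to compound 3 (within the scatter), and nitro in place of methoxy at the same carbon shows no change at the digits printed from compound 1 to compound 3 (within the scatter), so all three groups measured at this carbon now stand level. The new exchange is also a larger one by count than the earlier step: nitro enters with 3 heavy atoms and 2 hydrogen-bond acceptors where chloro leaves with 1 heavy atom and 0 hydrogen-bond acceptors, and even so the number stays within the scatter, which the pair of compound 1 and compound 2 alone could not show. No independent measurement bears on why the values coincide, so the result stands here as an observation only.

The compounds shown cover only methoxy, chloro and nitro at this one carbon, so it remains open whether an amine, a carboxylic acid or a longer chain there would move the number beyond the scatter. From the compounds shown here alone, it also remains open whether the same exchanges would stay as flat at another carbon of that ring or with a different group in place of the hydroxyl on the shared core.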